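Chloro for Hydroxy on a Weak Imine

The source may report more compounds than this note shows. Statements on the series, on what has been measured and on what is new or still open speak of the compounds shown alone.

Three compounds share a core and differ at the group on the imine or amide arm. Compound 1 `N#Cc1ncn(Cc2ccccc2Cl)c1NC(=O)c1ccccc1` gives 13400 nM in a functional assay on NCI-H460 cells (Homo sapiens) for antiproliferative activity, read by MTT assay; a lower number here means a stronger inhibitor, a higher number a weaker inhibitor. Compound 2 `COc1ccc(OC)c(/C=N/c2c(C#N)ncn2Cc2ccccc2Cl)c1` gives 28300 nM in this assay. Compound 3 `N#Cc1ncn(Cc2ccccc2Cl)c1/N=C/c1ccc(O)cc1` returns only a limit, > 40000 nM, so its true value is not known; it sits at the limit of > 40000 nM in this assay, at which 1 of the 3 values shown sits, the weak end of what is shown.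

Compound 4 `N#Cc1ncn(Cc2ccccc2Cl)c1/N=C/c1ccc(Cl)cc1` differs from compound 3 by chloro in place of hydroxy on an aromatic carbon. Within the data shown here, no measured step of this kind exists here, and the surrounding compounds all sit at weak values, so the expected step from compound 3 to compound 4 is an at least 1.3-fold lower number from compound 3 to compound 4 (0.12 log units; that floor lies within the scatter), with no clear direction beyond the scatter. Compound 4 is therefore estimated at 30000 nM, within 10000 nM to 80000 nM.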

Compound 4, half-maximal inhibitory concentration: 28100 nM
Compound 4: middle estimate off by 1.1-fold (0.03 log units), on the high side, and the stated range covers the measured number.
By their numbers in this assay, from the lowest: compound 1; then compounds 4 and 2 (each within the scatter of the next). At a limit, above all of these: compound 3.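

Swapping 4-hydroxyphenyl for 4-chlorophenyl on the imine arm gives the only measured change at this position, an at least 1.4-fold lower number from compound 3 to compound 4 (0.15 log units; that floor lies within the scatter) in this assay. With chloro there, the compound returns a number rather than a limit, yet the printed floor shows no change beyond the scatter. The true size of the step stays unknown because compound 3 stands at a limit of the assay: the limit of > 40000 nM in this assay, at which 1 of the 4 values shown sits.

On these data alone, whether an amine or a carboxylic acid on this aromatic carbon would move the number beyond the scatter remains open. So does the effect of chloro on the benzoyl ring of compound 1.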